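Geometry of the exocyclic double bond and loss of potency

This account rests on a few compounds, and the source may have more. Where it says the series, first, only, none or still open, it means among the compounds named here.

Of the compounds shown here, three of one shared core have been measured in a functional assay for agonist activity, with Homo sapiens as the target; a lower number here means a stronger inhibitor, a higher number a weaker inhibitor. Compound 1, `O=C(O)CCC/C=C1\C[C@H]2C[C@@H](O)[C@H](/C=N/OCc3ccc(F)cc3)[C@H]2C1`, gives 1900 nM there. Compound 2, `O=C(O)CCC/C=C1\C[C@H]2C[C@@H](O)[C@H](/C=N\OC(c3ccccc3)c3ccccc3)[C@H]2C1`, gives 1600 nM, a value within the scatter of compound 1, so no order between them can be claimed. Compound 3, `O=C(O)CCC/C=C1/C[C@H]2C[C@@H](O)[C@H](/C=N\OC(c3ccccc3)c3ccccc3)[C@H]2C1`, gives 23000 nM, the highest number of the three; compound 1 thus stands second highest, and its gap to compound 3 lies beyond the scatter. Among the compounds with values here, the one measured step that changes only configuration, a 14-fold higher number from compound 2 to compound 3 (1.16 log units; beyond the scatter), rests on (the fact that compounds 2 and 3 differ only in the configuration as drawn).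

Compound 4, `O=C(O)CCC/C=C1/C[C@H]2C[C@@H](O)[C@H](/C=N/OCc3ccc(F)cc3)[C@H]2C1`, is the counterpart of compound 1 with the same change: the two compounds have the same atoms and bonds and differ only in configuration as drawn: 1 of 6 stereo elements differ; a double bond is drawn E in compound 1 and Z in compound 4. Within the data shown here, the step from compound 2 to compound 3 is the only measured guide and was large, so a step of similar size toward a higher number is expected here, a 13-fold higher number from compound 1 to compound 4 (1.12 log units; beyond the scatter). Compound 4 is therefore estimated to give 25000 nM in this assay, in the range 8000 nM to 80000 nM.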

Compound 4, half-maximal inhibitory concentration: 14000 nM
For compound 4 the middle estimate is 1.8-fold (0.25 log units) above the measured one; the range from low to high includes it.
By their numbers in this assay, from the lowest: compounds 2 and 1 (each within the scatter of the next); then compounds 4 and 3 (each within the scatter of the next).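

In this assay, the change at the exocyclic double bond from E to Z now also raises the number with a different side chain on the shared core: a 7.4-fold higher number from compound 1 to compound 4 (0.87 log units; beyond the scatter). The loss of potency is therefore not tied to a single side chain, since it appears in both pairs that differ in this way, and neither pair goes against it. This second step rests on a single structural difference: the fact that compounds 1 and 4 differ only in the configuration as drawn.

The compounds shown leave open whether the same rise would follow the same change of geometry with an amine on the side chain, or with an amide in place of the carboxylic acid. They also leave open whether it would persist with a longer chain carrying that acid.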